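The compounds below may be only part of what the source reports. "The series", "measured", "known", "first", "only" and "open" are said of these compounds alone.

- Compound 1 `COc1cccc2nnn(CC(=O)N[C@@H](C)c3ccc(C)cc3)c(=O)c12`: 16 mL/min/kg
- Compound 2 `C[C@H](NC(=O)Cn1nnc2ccccc2c1=O)c1ccc(OC(F)F)cc1`: < 5.7 mL/min/kg

Both compounds were tested in an ADME assay on cells (Hepatocyte, Homo sapiens) for metabolic stability; a higher number here means faster removal of the compound, a lower number slower removal. Compound 2 gives only a limit of this assay, < 5.7 mL/min/kg, and not a number. Compound 2 therefore stands at the limit of < 5.7 mL/min/kg in this assay, at which 1 of the 2 values shown sits.

The next molecule, compound 3 `COc1cccc2nnn(CC(=O)N[C@@H](C)c3ccc(OC(F)F)cc3)c(=O)c12`, is built from compound 2 by one change: methoxy in place of hydrogen on an aromatic carbon. In words, a methoxy takes the place of a hydrogen on an aromatic carbon.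

Going by the values given here, no measured pair shows this change on its own, so any forecast here is rough. Among the compounds with values here, the only true number available is from compound 1, at 16 mL/min/kg, and it leans the expectation towards faster removal rather than slower. The expected size of the move is modest, given as an at least 1.5-fold higher number from compound 2 to compound 3 (0.19 log units; that floor lies within the scatter). The estimate for compound 3 is 9 mL/min/kg, with an expected range of 5 mL/min/kg to 17 mL/min/kg.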

Compound 3, clearance in the Hepatocyte assay: < 4.7 mL/min/kg
Compound 3 was reported as a limit (the forecaster's own chance of this, stated with the estimate: 30%); middle value at least 1.9-fold (0.28 log units) from the limit.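

In the Hepatocyte assay, compound 2 and compound 3 each give only a limit, so the step from hydrogen to methoxy on the aromatic carbon cannot be read. With the methoxy in place on both compounds, the Hepatocyte assay does show what the other end of the molecule contributes: difluoromethoxy in place of methyl on an aromatic carbon gives an at least 3.4-fold lower number from compound 1 to compound 3 (0.53 log units; beyond the scatter). The methoxy change itself can be read in a physicochemical assay for solubility, read by HPLC, in phosphate buffer, with a stated time of 16 h, at pH 6.8; on this read-out higher numbers stand for higher solubility and lower numbers for lower solubility: the measured solubility of compound 2, 2400 nM, and of compound 3, 9600 nM, a 4.0-fold higher number (0.60 log units; beyond the scatter) In the physicochemical assay compound 2 gives 2400 nM and compound 3 gives 9600 nM.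

On these data alone, how far the methoxy alone moves clearance stays open, as neither compound gives a true number there. Also open, as far as these compounds go, is whether an amine or a longer chain on the same aromatic carbon would stay at a limit in the Hepatocyte assay and still match the solubility of compound 3 in the physicochemical assay.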